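The source may report more compounds than this note shows. Statements on the series, on what has been measured and on what is new or still open speak of the compounds shown alone.

Compound 1 `O=C(O)CCC/C=C\C[C@H]1C(=O)C[C@@H](O)[C@@H]1/C=C/[C@@H](O)COc1ccccc1` tested in a functional assay on CHO cells for agonist activity at prostaglandin F2-alpha receptor (Homo sapiens), read by fluorescence and calcium flux (on this read-out higher numbers stand for an effect only at larger amounts of compound and lower numbers for an effect already at smaller amounts), gives 16 nM. Among the compounds with values here, compound 2 `O=C(O)CCC[C@@H]1CC[C@@H]2[C@@H](/C=C/[C@@H](O)COc3ccccc3)[C@H](O)C[C@@H]2O1` in this assay gives 4.1 nM, the lowest of the two numbers so far; the gap to compound 1 lies beyond the usual scatter.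

Compound 3 `O=C(O)CCC[C@H]1CC[C@@H]2[C@@H](/C=C/[C@@H](O)COc3ccccc3)[C@H](O)C[C@@H]2O1` differs from compound 2 only as follows: the two compounds have the same atoms and bonds and differ only in configuration as drawn: 1 of 7 stereo elements differ; a stereocentre at a saturated ring carbon is drawn R in compound 2 and S in compound 3. Within the data shown here, no measured pair carries the same change, so its size is unknown here. Inverting a stereocentre on the shared core is expected to move the number upward in this assay, by an estimated step of a 6.1-fold higher number from compound 2 to compound 3 (0.79 log units; beyond the scatter). Compound 3 is therefore expected to give about 25 nM in this assay, within a range of 5 nM to 150 nM.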

Compound 3, half-maximal effective concentration: 7.1 nM
For compound 3 the middle estimate is 3.5-fold (0.55 log units) above the measured one; the range from low to high includes it.
By their numbers in this assay, from the lowest: compounds 2 and 3 (each within the scatter of the next); then compound 1.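

In this assay the change from R to S at this saturated ring carbon comes out as a 1.7-fold higher number from compound 2 to compound 3 (0.24 log units; within the scatter), so on this read-out the two configurations cannot be told apart. The earlier compounds gave no measured pair for this change, and this pair isolates it to a single stereocentre: the fact that compounds 2 and 3 differ only in the configuration as drawn

Open, going by these compounds, is whether the configuration at this ring carbon stays without a readable effect when the carboxylic acid is replaced by a methyl ester or when the acid-bearing chain is longer.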